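Swapping the ring on the amide carbonyl: from oxadiazole to pyridine

The source may report more compounds than this note shows. Statements on the series, on what has been measured and on what is new or still open speak of the compounds shown alone.

Measured so far:
Compound 1 `Cc1c(NC(=O)c2ccc(C(C)(C)C)cc2)cccc1-c1ccnc2[nH]c(-c3cnn(C)c3)nc12`: 0.6 10^-6 cm/s
Compound 2 `Cn1cc(-c2nc3c(-c4ccc(CNC(=O)c5nc(C6(C)CC6)no5)c(F)c4)ccnc3[nH]2)cn1`: 2.8 10^-6 cm/s
Compound 3 `Cn1cc(-c2nc3c(-c4ccc(CNC(=O)c5noc(C(C)(C)C)n5)c(F)c4)ccnc3[nH]2)cn1`: 2.5 10^-6 cm/s

These were measured in an ADME assay on Caco-2 cells (Homo sapiens) for permeability, in the apical to basolateral direction; a higher number here means that the compound crosses the layer faster, a lower number that the compound crosses the layer more slowly. Compound 3 stands second highest of the three, with compound 2 nearest and compound 1 furthest: a 1.1-fold lower number from compound 2 to compound 3 (0.05 log units; within the scatter), while compound 1 sits well below.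

Compound 4 `Cn1cc(-c2nc3c(-c4ccc(CNC(=O)c5ccc(C(C)(C)C)cn5)c(F)c4)ccnc3[nH]2)cn1` has not been measured. It differs from compound 3 by 5-(tert-butyl)pyridin-2-yl in place of 5-(tert-butyl)-1,2,4-oxadiazol-3-yl on a carbonyl carbon. Among the compounds with values here, the only step known on this carbonyl carbon is a 1.1-fold lower number from compound 2 to compound 3 (0.05 log units; within the scatter), and no measured pair exchanges a five-membered ring for a six-membered one, so the step is expected to be small, at most modestly upward: a 1.4-fold higher number from compound 3 to compound 4 (0.15 log units; within the scatter). Compound 4 is therefore estimated at 3.5 10^-6 cm/s, within a range of 1.2 10^-6 cm/s to 10 10^-6 cm/s.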

Compound 4, apparent permeability: 0.3 10^-6 cm/s
The estimate for compound 4 lay 12-fold (1.07 log units) above the measured number, outside the stated range (below it).
By their numbers in this assay, from the lowest: compounds 4 and 1 (each within the scatter of the next); then compounds 3 and 2 (each within the scatter of the next).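

In this assay, the group on this carbonyl carbon can shift the number well beyond the scatter: 5-(tert-butyl)pyridin-2-yl in place of 5-(tert-butyl)-1,2,4-oxadiazol-3-yl gives an 8.3-fold lower number from compound 3 to compound 4 (0.92 log units; beyond the scatter). The other oxadiazole gives a similar result, with a 9.3-fold lower number from compound 2 to compound 4 (0.97 log units; beyond the scatter). Nothing measured here says why the number falls. Still open, from the compounds shown here alone, is whether ring size or the count of ring hetero atoms matters more. A phenyl or pyrimidin-2-yl ring carrying the same tert-butyl group would help separate the two.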